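Dimethylamino in place of methoxyethylamino on a shared core

This account rests on a few compounds, and the source may have more. Where it says the series, first, only, none or still open, it means among the compounds named here.

compound 1, `COCCNc1nc(NCC2CC2)cc(-c2ccccn2)n1`: 2200 nM
compound 2, `CNc1nc(NCc2ccncc2)cc(-c2ccccn2)n1`: 87 nM

In a functional assay on HEK293 cells for agonist activity at G-protein coupled receptor 39 (Homo sapiens), read by inositol phosphate accumulation (a lower number here means that less compound is needed, a higher number that more compound is needed for the effect), compound 1 stands highest of the two numbers; its nearest neighbour, compound 2, gives 87 nM, a lower number beyond the scatter. Compound 3 `CN(C)c1nc(NCC2CC2)cc(-c2ccccn2)n1` differs from compound 1 by dimethylamino in place of (2-methoxyethyl)amino on an aromatic carbon. For the measured compounds named here, no pair of measured compounds shares exactly this change, and compound 2 differs from compound 1 in two places, so its value shows only that a small amino group on that carbon goes with a low number. Compound 3 is expected to show a moderately lower number, a 2.8-fold lower number from compound 1 to compound 3 (0.44 log units; beyond the scatter). The estimate for compound 3 is 800 nM, with a range from 150 nM to 4000 nM.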

Compound 3, half-maximal effective concentration: > 25000 nM
Compound 3: a limit, no number (the forecaster's own chance of this, stated with the estimate: 5%); middle value at least 31-fold (1.49 log units) from the limit.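

On the core of compound 1, a change at this aromatic carbon between two ring nitrogen atoms moves the result sharply in this assay, giving an at least 11-fold higher number from compound 1 to compound 3 (1.05 log units; beyond the scatter). Dimethylamino enters with 0 hydrogen-bond donors where (2-methoxyethyl)amino had 1, and the chain is shortened as well, so two things change at once. For compound 3 the result is a limit and not a number, so the step has no known upper end: the limit of > 25000 nM in this assay, at which 1 of the 3 values shown sits.

The compounds shown leave open whether the loss of the amino hydrogen or the loss of the methoxyethyl chain matters more. Ethylamino and (2-methoxyethyl)(methyl)amino at this carbon would each separate the two.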